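The source may hold more compounds than are shown below. What is called first, only, known or untested is meant among the compounds shown, and "the series" means these compounds.

Measured so far in an assay on isolated protein for inhibition of Aromatase (Homo sapiens); a lower number here means a stronger inhibitor, a higher number a weaker inhibitor:

compound 1, `COCOc1ccc(C(=O)/C=C/c2ccc(OCOC)c(CC=C(C)C)c2)c(O)c1`, > 242000 nM
compound 2, `COCOc1ccc(C(=O)/C=C/c2ccc(OC)c(CC=C(C)C)c2)c(O)c1`, > 261000 nM
compound 3, `COCOc1ccc(/C=C/C(=O)c2ccc(OC)cc2O)cc1CC=C(C)C`, > 261000 nM

Compound 3 stands at a limit of this assay, > 261000 nM, which is not a number but the highest concentration tested without reaching half inhibition. Compound 1 likewise sits at a limit, > 242000 nM. Compound 2 sits at a limit as well, > 261000 nM. All three shown values are therefore limits, the limit of > 242000 nM in this assay, at which 1 of the 3 values shown sits, and (the limit of > 261000 nM in this assay, at which 2 of the 3 values shown sit), and no compound can be ranked against another.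

Compound 4 is `COc1ccc(C(=O)/C=C/c2ccc(O)c(CC=C(C)C)c2)c(O)c1`. It differs from compound 3 by hydrogen in place of methoxymethyl on an oxygen on an aromatic ring; cut one bond further out, the change reads methoxymethoxy to hydroxy. For the measured compounds named here, the two measured steps that resemble it, a step that the two limits leave unreadable from compound 1 to compound 2 and a step that the two limits leave unreadable from compound 1 to compound 3, both run between limits, so their size cannot be read; they say only that trimming this protecting group elsewhere did not bring a value into the measurable range.

With nothing readable to lean on, compound 4 is estimated at 40000 nM, between 5000 nM and 300000 nM. That estimate means a step of an at least 6.5-fold lower number from compound 3 to compound 4 (0.81 log units; beyond the scatter) in this assay, and a fair chance remains that compound 4 again gives only a limit.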

Compound 4, half-maximal inhibitory concentration: > 295000 nM
Compound 4 gave a limit, no number; the forecaster's own chance of this, stated with the estimate: 50%; middle value at least 7.3-fold (0.86 log units) from the limit.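

In this assay compound 4 gives > 295000 nM, which is again a limit and not a number. Compound 3 also stands at a limit, so the step between compound 3 and compound 4 cannot be read. The compounds shown leave open whether replacing methoxymethyl with hydrogen changes inhibition at all, and what true value any of them has.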